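The compounds below may be only part of what the source reports. "The series", "measured", "known", "first", "only" and "open" are said of these compounds alone.

Compounds measured in an assay for activation of Adrenergic receptor alpha-1 (Rattus norvegicus); on this read-out higher numbers stand for an effect only at larger amounts of compound and lower numbers for an effect already at smaller amounts:
compound 1, `C1=C(CCN2CCN(c3cccc4c3OCCO4)CC2)c2ccccc2CCC1`
compound 2, `Clc1cccc2c1CC2CCCN1CCN(c2cccc3c2OCCO3)CC1`
compound 3, `C1=C(CCN2CCN(c3cccc4c3OCCO4)CC2)c2ccccc2C1`

In this assay compound 2 gives 1.25 mg/kg and compound 3 gives 0.3 mg/kg. For compound 1 only a limit of the assay is recorded, > 2.5 mg/kg; (the limit of > 2.5 mg/kg in this assay, at which 1 of the 3 values shown sits). Compound 3 thus holds the lowest of the two numeric values, the nearest being compound 2, a gap beyond the scatter. Compound 4, `c1ccc2c(c1)CC(CCN1CCN(c3cccc4c3OCCO4)CC1)C2`, is not yet measured and differs from compound 3 in one place: a group of 9 heavy atoms (9 carbon; one five-membered non-aromatic ring of carbon only, one six-membered aromatic ring of carbon only) in place of a group of 9 heavy atoms (9 carbon; one five-membered non-aromatic ring of carbon only, one six-membered aromatic ring of carbon only), on a saturated chain carbon, two bonds along the chain from an amine nitrogen in a ring. Going by the values given here, no step between measured compounds is available for this change, so the expectation rests on the values alone: a modest move toward a higher number is expected, a 2.3-fold higher number from compound 3 to compound 4 (0.37 log units; beyond the scatter). For compound 4 the estimated value is 0.7 mg/kg, within a range of 0.3 mg/kg to 2 mg/kg.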

Compound 4, dose for half-maximal effect: 0.66 mg/kg
Beside the measured number, compound 4's estimate is 1.1-fold (0.03 log units) above it, and the stated range covers the measured number.
By their numbers in this assay, from the lowest: compound 3; then compounds 4 and 2 (each within the scatter of the next). At a limit, above all of these: compound 1.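

Going by these compounds alone, compound 3 and compound 4 form the first pair that differs in one place, and in this assay the change gives a 2.2-fold higher number from compound 3 to compound 4 (0.34 log units; beyond the scatter). The group entering, 2,3-dihydro-1H-inden-2-yl, has the same heavy-atom count and ring types as the group leaving, but lacks its double bond outside aromatic rings, so this single change shifts the read-out only modestly. No available measurement bears on the reason for this step.

Still open, going by these compounds, is how a hydroxyl or an amine on the 2,3-dihydro-1H-inden-2-yl group would read in this assay. On these data alone, a longer chain to the amine nitrogen in a ring is equally open.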